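The source may hold more compounds than are shown below. What is called first, only, known or untested is meant among the compounds shown, and "the series" means these compounds.

Series notes. Compound 1 `C#CCN(CCCCOc1ccc2ccc(=O)oc2c1)Cc1cccc(OC)c1`, compound 2 `C#CCN(CCCCOc1ccc2ccc(=O)oc2c1)Cc1ccc(C(C)C)cc1` and compound 3 `C#CCN(CCCOc1ccc2ccc(=O)oc2c1)Cc1ccc(C(C)C)cc1` have been measured in an assay on isolated protein for inhibition of Amine oxidase [flavin-containing] B (Homo sapiens), read by fluorescence and Amplex Red, with stated times of 15 min and 20 min; a lower number here means a stronger inhibitor, a higher number a weaker inhibitor. Compound 1 gives 2340 nM, compound 2 gives 3500 nM, and compound 3 gives 7580 nM, the highest number of the three, with its step to compound 2 and to compound 1 each beyond the scatter. Compound 2 and compound 3 carry the same groups on the amine nitrogen; the difference between their two cores is not broken down here. Between compound 2 and compound 1 the change is 3-methoxyphenyl in place of 4-isopropylphenyl on a saturated chain carbon bound to an amine nitrogen, and it gave a 1.5-fold lower number from compound 2 to compound 1 (0.17 log units; within the scatter).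

Compound 4 `C#CCN(CCCOc1ccc2ccc(=O)oc2c1)Cc1cccc(OC)c1` has not yet been measured in this assay. Going by the values given here, it arises from compound 3 by 3-methoxyphenyl in place of 4-isopropylphenyl on a saturated chain carbon bound to an amine nitrogen, the same change as the one between compound 2 and compound 1, now on the core of compound 3. Among the compounds with values here, the expected step from compound 3 to compound 4 is a 1.5-fold lower number from compound 3 to compound 4 (0.16 log units; within the scatter), resting on the single earlier instance, where the same change gave a 1.5-fold lower number from compound 2 to compound 1 (0.17 log units; within the scatter); one instance is a thin base, so the span is kept wide. The estimated value for compound 4 in this assay is 5200 nM, with 2600 nM to 10500 nM as the likely range.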

Compound 4, half-maximal inhibitory concentration: 4590 nM
Compound 4: the middle estimate sits 1.1-fold (0.05 log units) above what was measured; measured number inside the range.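

In this assay the new step is a 1.7-fold lower number from compound 3 to compound 4 (0.22 log units; within the scatter). Set beside the earlier instance, the exchange of 4-isopropylphenyl for 3-methoxyphenyl reads alike on the two cores: the same change on two cores in this assay, a 1.5-fold lower number (0.17 log units; within the scatter) from compound 2 to compound 1 and a 1.7-fold lower number (0.22 log units; within the scatter) from compound 3 to compound 4, 1.1-fold (0.04 log units) apart, within the scatter of two such steps. This shows agreement between the two cores within the scatter, but each step also lies within the scatter, so it does not show that the exchange itself shifts the number, and two cores set no rule for a third.

The compounds shown leave open whether any group on a saturated chain carbon bound to an amine nitrogen would give a step beyond the scatter, for example a phenyl ring carrying a nitrile or a carboxylic acid in place of 3-methoxyphenyl. Also open, on these data alone, is whether this exchange would stay as small on a core with a longer chain than those of compound 1 and compound 3.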